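Exchanging Imidazolyl for Ethoxy on the Aryl Ketone Ring

This account rests on a few compounds, and the source may have more. Where it says the series, first, only, none or still open, it means among the compounds named here.

Of the compounds shown here, three built on one shared core have been measured in an assay on isolated protein for inhibition of Amine oxidase [flavin-containing] B (Homo sapiens); a lower number here means a stronger inhibitor, a higher number a weaker inhibitor. Compound 1 `CCOc1ccc(C(=O)/C=C/c2ccc(C)cc2)cc1` gives 210 nM, and compound 2 `CCOc1ccc(C(=O)/C=C/c2ccc(Br)cc2)cc1` gives 210 nM. Compound 3 `CCc1ccc(/C=C/C(=O)c2ccc(-n3ccnc3)cc2)cc1` gives 320 nM, the highest of the three numbers, though its gaps to compound 1 and to compound 2 both lie within the scatter, so no order among the three can be claimed. Among the measured compounds shown here, the only single-point step measured so far, no change at the digits printed from compound 1 to compound 2 (within the scatter), shows that a methyl-to-bromo exchange on that aromatic carbon left the number unchanged.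

Compound 4 `CCOc1ccc(C(=O)/C=C/c2ccc(CC)cc2)cc1` differs from compound 3 in one place: ethoxy in place of 1H-imidazol-1-yl on an aromatic carbon. For the measured compounds named here, no measured step covers this exchange. Compound 1 and compound 2 carry the same ethoxy group that enters in compound 4, but each also differs from compound 3 at the far ring, so only their values can be set beside it, and those values sit close to the value of compound 3. Compound 4 is therefore expected near 220 nM because the ethoxy-bearing compound 1 gives 210 nM. The expected step from compound 3 to compound 4 is a 1.5-fold lower number from compound 3 to compound 4 (0.16 log units; within the scatter), no larger than the scatter. Compound 4 is estimated to fall between 90 nM and 550 nM.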

Compound 4, half-maximal inhibitory concentration: 210 nM
Compound 4: the middle estimate sits 1.0-fold (0.02 log units) above what was measured; measured number inside the range.
By their numbers in this assay, from the lowest: compounds 1, 2, 4 and 3 (each within the scatter of the next).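

In this assay, among the compounds shown here, the step that places ethoxy on the aromatic carbon in place of 1H-imidazol-1-yl gives a 1.5-fold lower number from compound 3 to compound 4 (0.18 log units; within the scatter) and is the first direct reading at this position. A five-membered aromatic ring with two hetero atoms and an ethoxy group with no ring therefore cannot be told apart here on the far side of the ketone, para to a large group. At the far ring, the step to ethyl in place of bromo gives no change at the digits printed from compound 2 to compound 4 (within the scatter), and methyl in place of hydrogen on a saturated chain carbon bound to an aromatic carbon gives no change at the digits printed from compound 1 to compound 4 (within the scatter), so the lack of change seen earlier between methyl and bromo now extends to ethyl. No evidence is at hand that bears on this result.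

Going by these compounds, whether the same position would hold its number with an amine, a carboxylic acid or a longer chain such as butoxy remains open, and so does the effect of leaving bare hydrogen there. All four compounds lie within the scatter of their neighbours, so the limits of what either position tolerates have yet to be reached.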